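Removing the fluoro from compound 2

The compounds below may be only part of what the source reports. "The series", "measured", "known", "first", "only" and "open" are said of these compounds alone.

- compound 1 `O=C(Nc1cc(-c2ccccn2)n[nH]1)N1CCN(c2ccc(F)cc2)CC1` gives 30.8 mL.min-1.g-1
- compound 2 `O=C(Nc1cc(-c2ccccn2)n[nH]1)N1CCC(c2ccc(F)cc2)CC1` gives 42.5 mL.min-1.g-1

Both numbers come from an ADME assay on liver for metabolic stability, with Liver microsome (Homo sapiens) as the target, using microsomes; on this read-out higher numbers stand for fast clearance and lower numbers for slow clearance. The two compounds share one core and the same 4-fluorophenyl group, and they differ elsewhere. Compound 2 stands at 42.5 mL.min-1.g-1, within the usual scatter of compound 1, so these two readings cannot be told apart.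

The next compound to be read is compound 3 `O=C(Nc1cc(-c2ccccn2)n[nH]1)N1CCC(c2ccccc2)CC1`. It is compound 2 with hydrogen in place of fluoro on an aromatic carbon, para to a large group, so that the 4-fluorophenyl becomes phenyl: hydrogen in place of fluoro on an aromatic carbon.

Going by the values given here, no pair of measured compounds shows this change, and the expectation therefore has little to rest on. In this assay a slight rise is expected at most, with no step beyond the scatter. The expected change is a 1.1-fold higher number from compound 2 to compound 3 (0.05 log units; within the scatter). For compound 3 the estimated value is 48 mL.min-1.g-1, with an expected range from 26 mL.min-1.g-1 to 85 mL.min-1.g-1.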

Compound 3, intrinsic clearance in microsomes: 15.3 mL.min-1.g-1
For compound 3 the middle estimate is 3.1-fold (0.50 log units) above the measured one, and the stated range ends above it.
By their numbers in this assay, from the lowest: compounds 3, 1 and 2 (each within the scatter of the next, the first and the last beyond it).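

Hydrogen in place of fluoro on this aromatic carbon, para to a large group, proves not to be a silent change in this assay: it gives a 2.8-fold lower number from compound 2 to compound 3 (0.44 log units; beyond the scatter), so the substituent at this position does bear on the read-out, and here the compound with the fluoro is the one on the faster-clearance side. Going by these compounds alone, the earlier pair could not show this, since its two compounds share the 4-fluorophenyl group and differ elsewhere, whereas this is the first step that changes one place only, although it still rests on a single pair around a single core. Nothing among the available data accounts for the size or direction of this step.

From the compounds shown here alone, whether the same replacement of 4-fluorophenyl by phenyl would act alike on the core of compound 1 remains open. The compounds shown also leave open how this assay would read with a chloro, a methoxy or a nitrile on this same aromatic carbon, and so whether the step belongs to fluoro alone or extends to other groups there.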